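The source may hold more compounds than are shown below. What is called first, only, known or untested is meant among the compounds shown, and "the series" means these compounds.

Series notes. Compound 1 `CC1=CSC(O)(c2cccc([N+](=O)[O-])c2)c2noc(=O)n21`, compound 2 `CC1=CSC(O)(c2cccc(C(F)(F)F)c2)c2noc(=O)n21`, compound 3 `CC1=CSC(O)(c2ccccc2)c2noc(=O)n21` and the still unmeasured compound 4 `CC1=CSC(O)(c2cccc(Cl)c2)c2noc(=O)n21` share one core and differ only in the substituent on the pendant phenyl ring. In a functional assay on A2780 cells (Homo sapiens) for antiproliferative activity, read by MTT assay, with a stated time of 3 days (a higher number here means a weaker inhibitor, a lower number a stronger inhibitor), compound 1 gives 159000 nM and compound 2 gives 60000 nM. For compound 3 this assay reports only a limit, > 100000 nM, so compound 3 stands at the limit of this assay without a number of its own. The change to compound 4 is chloro in place of hydrogen on an aromatic carbon. Steps on record are a 2.7-fold lower number from compound 1 to compound 2 (0.42 log units; beyond the scatter), a step that the limit leaves unreadable from compound 1 to compound 3 and an at least 1.6-fold higher number from compound 2 to compound 3 (0.22 log units; that floor lies within the scatter); the last, exchanging a substituent for hydrogen at the same position, bears most directly, and the limit of > 100000 nM in this assay, at which 1 of the 3 values shown sits, caps what can be read. Compound 4 is expected near 100000 nM, within 40000 nM to 250000 nM. The expected step is a number no higher from compound 3 to compound 4 (the limit leaves the size open).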

Compound 4, half-maximal inhibitory concentration: > 100000 nM
Compound 4 gave a limit, no number; the forecaster's own chance of this, stated with the estimate: 45%; the middle value sits exactly at the limit.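

In this assay, chloro on the aromatic carbon meta to a large group leaves compound 4 with only a limit, so a second compound in the series has no number of its own: the limit of > 100000 nM in this assay, at which 2 of the 4 values shown sit. Chloro in place of trifluoromethyl gives an at least 1.6-fold higher number from compound 2 to compound 4 (0.22 log units; that floor lies within the scatter), so this change sets no order between the two. The steps from compound 3 and from compound 1 to compound 4 cannot be read.

Going by these compounds, whether chloro differs from hydrogen at this position stays open. Also open, on these data alone, is how an amine or a carboxylic acid at this place would read in this assay.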